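The compounds below may be only part of what the source reports. "The series", "measured", "known", "first", "only" and "open" are said of these compounds alone.

Measured compounds:
compound 1 `O=C(/C(=C\c1ccc(Cl)cc1)Sc1ccc(Br)cc1)c1ccc(Br)cc1`: 1000 nM
compound 2 `Cc1ccc(S(=O)(=O)/C(=C/c2sccc2C)C(=O)c2ccc(Br)cc2)cc1`: 25000 nM
compound 3 `CCOc1ccc(/C=C(/Sc2ccc(C)cc2)C(=O)c2ccc(Cl)cc2)cc1OC`: 25000 nM

Three compounds from this series were tested in a functional assay on DU-145 cells (Homo sapiens) for inhibition, read by trypan blue exclusion, with a stated time of 96 h; on this read-out lower numbers stand for stronger inhibition of growth and higher numbers for weaker inhibition of growth. Compound 1 gives 1000 nM, the lowest of the three numbers. Compound 2 gives 25000 nM and compound 3 gives 25000 nM; both of these lie well beyond the usual scatter from the value of compound 1, so compound 1 stands as the most potent of the measured set. Among the compounds with values here, neither compound 2 nor compound 3 differs from compound 1 in a single place, so no single structural step between measured compounds can be read from these data.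

The unmeasured compound 4 `COc1ccc(/C=C(/Sc2ccc(Br)cc2)C(=O)c2ccc(Br)cc2)cc1` is reached from compound 1 by one change: methoxy in place of chloro on an aromatic carbon Cut one bond further out, the change reads 4-chlorophenyl to 4-methoxyphenyl. Compound 3, which also carries an alkoxy-bearing ring at this side of the molecule, gives a far higher number than compound 1, but it differs in several other places as well, so it cannot settle the question. In the absence of a measured step, a modest rise in the number is expected, with a fair chance that it stays within the scatter; the step from a 2.0-fold higher number from compound 1 to compound 4 (0.30 log units; within the scatter) is estimated in this spirit. Compound 4 is therefore expected at 2000 nM, within 500 nM to 10000 nM.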

Compound 4, concentration for 50% growth inhibition: 25000 nM
Estimate against measurement, compound 4: 13-fold (1.10 log units) below, and the stated range ends below it.
By their numbers in this assay, from the lowest: compound 1; then compounds 2, 3 and 4 (each within the scatter of the next).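

Methoxy in place of chloro on this aromatic carbon, para to a large group, gives a 25-fold higher number from compound 1 to compound 4 (1.40 log units; beyond the scatter) in this assay. Within the data shown here, this is the first single-place comparison in the set, and it shows that the group at this position matters greatly: with the rest of the molecule unchanged, the chloro compound inhibits growth far more strongly than its methoxy counterpart, something compound 2 and compound 3 could not show, since each differs from compound 1 in several places. Nothing measured here explains the size of this step.

From the compounds shown here alone, with only chloro and methoxy seen at this position, it remains open whether the strong inhibition is particular to chloro or extends to other groups, such as fluoro, methyl, trifluoromethyl or an amine. The compounds shown also leave open whether the same exchange would have a step of similar size on another background, for example one carrying the sulfonyl link found in compound 2.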